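A few compounds are considered here, and "the series" means these few. Any claim that something is new, unique, unknown or untested is made for them only; others in the source may bear on it.

Compound 1 `O=C1c2ccccc2N(Cc2ccccc2)S(=O)(=O)N1COCc1ccccc1` gives 49000 nM in a functional assay on HEL cells (Homo sapiens); a higher number here means that more compound is tolerated, a lower number that less compound is tolerated.
Compound 2 `O=C1c2ccccc2N(Cc2ccc(Cl)cc2)S(=O)(=O)N1Cc1ccccc1` gives only a limit in this assay, > 5000 nM.
Compound 3 `O=C1c2ccccc2N(Cc2ccccc2)S(=O)(=O)N1Cc1ccccc1Cl` gives 200000 nM in this assay.

Compound 2 therefore stands nowhere definite on the numbers shown: its result is a limit of the assay, not a measured value, and it is the one of the three that sits at that limit (the limit of > 5000 nM in this assay, at which 1 of the 3 values shown sits). Compound 4 `O=C1c2ccccc2N(COCc2ccccc2)S(=O)(=O)N1Cc1ccccc1` differs from compound 2 by benzyloxy in place of 4-chlorophenyl on a saturated chain carbon bound to a sulfonamide nitrogen in a ring. Among the compounds with values here, the one measured step, a 4.1-fold higher number from compound 1 to compound 3 (0.61 log units; beyond the scatter), concerns a chlorophenyl group entering in place of benzyloxy at a different nitrogen of the shared core, and it raised the number modestly; read in the opposite direction it points, weakly, toward a lower number when benzyloxy enters in place of a chlorophenyl group. Compound 4 also carries the same two groups as compound 1, which gives 49000 nM. Since compound 2 has no number, the size of the step that the limit leaves unreadable from compound 2 to compound 4 can only be guessed, and compound 4 is expected to land near 40000 nM, within 10000 nM to 150000 nM.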

Compound 4, minimum cytotoxic concentration: 122000 nM
Beside the measured number, compound 4's estimate is 3.1-fold (0.48 log units) below it, within the range that was stated.
By their numbers in this assay, from the lowest: compound 1; then compounds 4 and 3 (each within the scatter of the next).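

The step from compound 2 to compound 4 cannot be read, because compound 2 has only a limit: the limit of > 5000 nM in this assay, at which 1 of the 4 values shown sits.
The compounds shown leave open how the number in this assay responds to benzyloxy in place of 4-chlorophenyl on a saturated chain carbon bound to a sulfonamide nitrogen in a ring.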